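Methyl to fluoro on the aryl ketone of compound 1

The source may report more compounds than this note shows. Statements on the series, on what has been measured and on what is new or still open speak of the compounds shown alone.

Three compounds of the series have been run in a functional assay on CCRF-CEM cells (Homo sapiens) for antiproliferative activity, read by MTT assay, with a stated time of 72 h, tested at 200 uM; on this read-out higher numbers stand for a weaker effect at the one concentration tested and lower numbers for a stronger effect. Compound 1 `Cc1ccc(C(=O)CC(=O)OC(C)Cn2cnc3c2c(=O)n(C)c(=O)n3C)cc1` gives 31.6% in this assay. Compound 2 `CC(Cn1cnc2c1c(=O)n(C)c(=O)n2C)OCc1cn(CCCn2nc3c(Br)c(Br)c(Br)c(Br)c3n2)nn1` gives 0% in this assay, and compound 3 `CC(Cn1cnc2c1c(=O)n(C)c(=O)n2C)OCc1cn(-c2cccc3ccccc23)nn1` gives 4.1% in this assay. On these numbers compound 1 stands highest, its nearest neighbour being compound 3 and its furthest compound 2, both gaps beyond the scatter, so at the concentration tested compound 1 shows the weakest effect of the three. Going by the values given here, compounds 2 and 3 carry a different linker and terminal group, so they show only where the wider series sits and give no step against compound 1.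

Compound 4 `CC(Cn1cnc2c1c(=O)n(C)c(=O)n2C)OC(=O)CC(=O)c1ccc(F)cc1` keeps the ester and the aryl ketone of compound 1 and differs in one place: fluoro in place of methyl on an aromatic carbon. Read one bond further out, this is (4-methylphenyl)carbonyl to (4-fluorophenyl)carbonyl. Among the compounds with values here, no measured pair in the set isolates this exchange, so there is no step to lean on. An exchange of one heavy atom for one heavy atom on the same aromatic carbon is expected to move the read-out little, and the step of a number 0.4 percentage points higher from compound 1 to compound 4 (within the scatter) is expected to lie within the scatter, with no clear direction. Compound 4 is therefore estimated at 32% in this assay, within a range of 14% to 50%.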

Compound 4, a percentage reported as activity, at one concentration (the size of the read-out at that concentration, not a potency): 20.1%
For compound 4 the middle estimate is 11.9 percentage points above the measured one; measured number inside the range.
By their numbers in this assay, from the lowest: compounds 2 and 3 (each within the scatter of the next); then compound 4; then compound 1.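

Going by these compounds alone, the aromatic carbon para to a large group is not a silent position in this assay: fluoro in place of methyl gives a number 11.5 percentage points lower from compound 1 to compound 4 (beyond the scatter), the first step that isolates a single place, and a modest one. The earlier compounds shown here could not show this, since compounds 2 and 3 differ from compound 1 in both linker and terminal group and so only marked where the wider series sits. Nothing measured on these compounds speaks to what lies behind the lower number, which stands here as an observation on one pair at one concentration.

As far as these compounds go, whether the step belongs to fluoro itself or simply to the loss of methyl remains open, and the same aromatic carbon bearing hydrogen, chlorine, a methoxy group or a trifluoromethyl group would separate the two readings. Also open, from the compounds shown here alone, is whether the same exchange would move the read-out in the same direction on the different linker and terminal groups of compounds 2 and 3, or only with the aryl ketone of compound 1.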